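A few compounds are considered here, and "the series" means these few. Any claim that something is new, unique, unknown or untested is made for them only; others in the source may bear on it.

Of the compounds shown here, three built on one shared core have been tested in a functional assay on Huh-7 cells (Homo sapiens) for inhibition, read by sulforhodamine B assay, with a stated time of 72 h; a lower number here means a stronger inhibitor, a higher number a weaker inhibitor. Compound 1 `COc1ccc2cc(C(C)c3nnc4n3N=C(c3ccc(OC(F)(F)F)cc3)CS4)ccc2c1` gives 16000 nM, compound 2 `COc1ccc2cc(C(C)c3nnc4n3N=C(c3ccc(Br)cc3)CS4)ccc2c1` gives 9300 nM, and compound 3 `COc1ccc2cc(C(C)c3nnc4n3N=C(c3ccc(Cl)cc3Cl)CS4)ccc2c1` gives 10700 nM. On these numbers compound 3 stands second highest of the three, but the gaps are small: a 1.5-fold lower number from compound 1 to compound 3 (0.17 log units; within the scatter) and a 1.7-fold lower number from compound 1 to compound 2 (0.24 log units; within the scatter) both stay within the scatter, so the three compounds cannot be separated in this assay.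

Compound 4 `COc1ccc2cc(C(C)c3nnc4n3N=C(c3ccc(Cl)cc3)CS4)ccc2c1` has not yet been measured. It differs from compound 3 by hydrogen in place of chloro on an aromatic carbon; the chloro that leaves sits on an aromatic carbon of a six-membered aromatic ring of carbon only, ortho to a large group and meta to a chloro group, so the 2,4-dichlorophenyl becomes a 4-chlorophenyl. The step that bears most on this is a 1.2-fold higher number from compound 2 to compound 3 (0.06 log units; within the scatter), where a 4-bromophenyl carrying a single halogen was replaced by the 2,4-dichlorophenyl with two, and the number hardly moved. Removing one of those two chlorines is therefore expected to produce no step beyond the scatter in either direction.

Compound 4 is expected to give 10000 nM, within a range from 5000 nM to 21000 nM. The step this estimate implies, a 1.1-fold lower number from compound 3 to compound 4 (0.03 log units; within the scatter), is expected to lie within the scatter.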

Compound 4, half-maximal inhibitory concentration: 5600 nM
Estimate against measurement, compound 4: 1.8-fold (0.25 log units) above, and the stated range covers the measured number.
By their numbers in this assay, from the lowest: compounds 4, 2, 3 and 1 (each within the scatter of the next, the first and the last beyond it).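

Removing the chloro that sits ortho to a large group, so that the 2,4-dichlorophenyl becomes a 4-chlorophenyl, gives a 1.9-fold lower number from compound 3 to compound 4 (0.28 log units; within the scatter) in this assay, so this position can lose its chloro without a change that can be told apart from ordinary assay variation. Exchanging one halogen for another on the single-halogen ring also stays inside that variation, at a 1.7-fold lower number from compound 2 to compound 4 (0.22 log units; within the scatter), while replacing trifluoromethoxy with chloro gives a 2.9-fold lower number from compound 1 to compound 4 (0.46 log units; beyond the scatter), a modest step and the first in this set that separates two compounds. Nothing available here explains why any of these steps has the size it has.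

The compounds shown carry only halogens or trifluoromethoxy on this phenyl ring, so it remains open whether an amine or a carboxylic acid on that ring would shift the number further in either direction. Also open, from the compounds shown here alone, is what a phenyl ring with no substituent at all, or one keeping only the chloro ortho to the large group, would give, so the contribution of each chloro on its own is not settled.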